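The source may report more compounds than this note shows. Statements on the series, on what has been measured and on what is new or still open speak of the compounds shown alone.

Measured compounds:
- compound 1 `Cc1cc(C)c(NC(=O)N(Cc2cccc(-c3nnn(C)n3)c2)C2CCCCCC2)c(C)c1`: in a functional assay on a cell-free system (plasma) with sterol O-acyltransferase, Soat (Rattus norvegicus) as the target (a lower number here means that less compound is needed, a higher number that more compound is needed for the effect), compound 1 gives only a limit, < 1 mg/kg.
- compound 2 `Cc1cc(C)c(NC(=O)N(Cc2cccc(-c3cn[nH]c3)c2)C2CCCCCC2)c(C)c1`: in this assay compound 2 gives 0.19 mg/kg.

Among the compounds with values here, compound 2 thus carries the only real number here, since the other value is a limit. Within the data shown here, the one step between them, a step that the limit leaves unreadable from compound 1 to compound 2, cannot be sized, as the limit of < 1 mg/kg in this assay, at which 1 of the 2 values shown sits, shows. Compound 3 `Cc1cc(C)c(NC(=O)N(Cc2cccc(-c3ccn(C)n3)c2)C2CCCCCC2)c(C)c1` differs from compound 2 by 1-methyl-1H-pyrazol-3-yl in place of 1H-pyrazol-4-yl on an aromatic carbon. Among the measured compounds shown here, no measured step of readable size bears on this change, so no shift beyond the usual scatter is expected. Compound 3 is therefore estimated at 0.3 mg/kg, between 0.1 mg/kg and 1 mg/kg. The expected step is a 1.6-fold higher number from compound 2 to compound 3 (0.20 log units; within the scatter).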

Compound 3, dose for half-maximal effect: < 1 mg/kg
Compound 3 ended at the assay's limit; the forecaster's own chance of this, stated with the estimate: 20%; the middle value lies beyond the limit too.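

The steps from compound 1 and from compound 2 to compound 3 cannot be sized, because compound 3 gives only a limit: the limit of < 1 mg/kg in this assay, at which 2 of the 3 values shown sit. From the compounds shown here alone, whether these ring swaps shift the dose in this assay stays open.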